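A few compounds are considered here, and "the series" means these few. Any claim that something is new, unique, unknown or untested is made for them only; others in the source may bear on it.

Working notes on the series, values from a physicochemical assay for solubility, read by HPLC, in phosphate buffer, measured as kinetic solubility, at pH 7.4; a higher number here means a more soluble compound, a lower number a less soluble compound:

- compound 1 `CCOC(=O)c1cc(-c2ccc(OC)cc2)n(-c2ccc(S(N)(=O)=O)cc2)c1C`: 16100 nM
- compound 2 `CC(=O)c1cc(-c2ccc(S(N)(=O)=O)cc2)n(-c2ccc(Cl)cc2)n1`: 86800 nM
- compound 3 `CCC(=O)c1cc(-c2ccc(S(N)(=O)=O)cc2)n(-c2ccc(F)cc2)n1`: 96800 nM

Compound 3, at 96800 nM, lies within the scatter of compound 2. Compound 1 gives a lower number than compound 3, and that gap lies beyond the scatter.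

The next compound to be read is compound 4 `CCC(=O)c1cc(-c2ccc(S(N)(=O)=O)cc2)n(-c2ccccc2)n1`. It differs from compound 3 by hydrogen in place of fluoro on an aromatic carbon, with hydrogen in place of fluoro on an aromatic carbon, para to a large group, taking 4-fluorophenyl to phenyl.

Within the data shown here, no two measured compounds differ in one place only, so the series offers no direct measure of this change. The nearest reference points are compound 2 at 86800 nM and compound 3 at 96800 nM. In this assay, no step beyond the scatter is expected in either direction. The expected change is a 1.0-fold lower number from compound 3 to compound 4 (0.01 log units; within the scatter), which is within the scatter. For compound 4 the estimated value is 95000 nM, with an expected range of 50000 nM to 140000 nM.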

Compound 4, solubility: 47200 nM
Estimate against measurement, compound 4: 2.0-fold (0.30 log units) above; the measured number lies below the stated range.
By their numbers in this assay, from the lowest: compound 1; then compounds 4, 2 and 3 (each within the scatter of the next, the first and the last beyond it).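

The pair gives the series its first comparison in a single place in this assay: going from 4-fluorophenyl to phenyl gives a 2.1-fold lower number from compound 3 to compound 4 (0.31 log units; beyond the scatter). This shows that the aromatic carbon para to a large group is not a silent position in this read-out, as the change of one fluoro to hydrogen there, with the rest of the structure held fixed, moves the number beyond the scatter, though only modestly. No measurement on hand bears on why the number moves with this change.

On these data alone, it stays open how other groups on that carbon, such as a nitrile, an amine or a carboxylic acid, would read. A single pair also leaves open whether this step carries over to other compounds of the series.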